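The source may hold more compounds than are shown below. What is called first, only, known or untested is meant among the compounds shown, and "the series" means these compounds.

Working notes on the series in an ADME assay on BaF3 cells (Mus musculus) for cytotoxicity; a higher number here means that more compound is needed for the effect, a lower number that less compound is needed. Compound 1 has the structure `CCCn1cc2c(Nc3ccc(OC(F)(F)F)cc3)ncnc2n1`. In this assay compound 1 gives > 10000 nM, which is a limit of the assay and not a number. Compound 2 has the structure `FC(F)(F)Oc1ccc(Nc2cc(-c3cn[nH]c3)ncn2)cc1`. In this assay compound 2 gives > 10000 nM, again a limit rather than a number. Compound 2 therefore stands at the limit of > 10000 nM in this assay, at which 2 of the 2 values shown sit, so no ordering between compound 1 and compound 2 can be read from these values.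

The unmeasured compound 3 has the structure `FC(F)(F)Oc1ccc(Nc2cc(-n3ccnc3)ncn2)cc1`. It differs from compound 2 by 1H-imidazol-1-yl in place of 1H-pyrazol-4-yl on an aromatic carbon.

Within the data shown here, no step between measured compounds is available for this series. The expected step that the limit leaves unreadable from compound 2 to compound 3 is none beyond the scatter, because compound 2 sits at the limit of > 10000 nM in this assay, at which 2 of the 2 values shown sit, and nothing measured points away from that limit. Compound 3 is therefore expected to give about 15000 nM, within a range of 5000 nM to 50000 nM, most likely reported again as a limit.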

Compound 3, half-maximal effective concentration: > 10000 nM
Compound 3 was reported as a limit; the forecaster's own chance of this, stated with the estimate: 85%; the middle value does not contradict the limit.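

Among these compounds, no step from compound 2 to compound 3 can be read in this assay because both values are limits of the assay and not numbers: the limit of > 10000 nM in this assay, at which 3 of the 3 values shown sit. The compounds shown leave open how far each lies from that limit and whether any change to the series gives a readable value.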